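The source may hold more compounds than are shown below. What is called first, only, known or untested is meant among the compounds shown, and "the series" means these compounds.

Measured so far:
compound 1 `CC1=C(N2CC2)C(=O)C(CC(C)OC(N)=O)=C(N2CC2)C1=O` 5.86
compound 2 `CCC1=C(N2CC2)C(=O)C(C(COC(N)=O)OC)=C(N2CC2)C1=O` 5.62
compound 3 `CCCC1=C(N2CC2)C(=O)C(CCC)=C(N2CC2)C1=O` 4.32

In a functional assay on L1210 cells (Mus musculus), with a stated time of 1 days (a higher number here means a more potent compound, by a factor of ten per unit of this negative logarithm, a lower number a less potent compound), compound 1 has the highest of the three numbers. Compound 2 sits close to it, within the usual scatter, so the two cannot be told apart; compound 3 lies well below, beyond the scatter. Compound 4 `CC(=O)C1=C(N2CC2)C(=O)C(C)=C(N2CC2)C1=O` is not yet measured. It differs from compound 1 in one place: a group of 3 heavy atoms (2 carbon, 1 oxygen; no ring) in place of a group of 7 heavy atoms (4 carbon, 1 nitrogen, 2 oxygen; no ring), on a double-bonded ring carbon. The group that leaves carries the carbamate, and the group that enters, acetyl, does not. The shared core of compound 1 is kept. Within the data shown here, with no step between measured compounds to lean on, and compound 3 giving only 4.32 without such a group, a downward step in this assay is expected, probably beyond the scatter. Compound 4 is therefore estimated at 5, between 4.3 and 5.7, a step of a number 0.86 log units lower from compound 1 to compound 4 (beyond the scatter).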

Compound 4, logarithm of the reciprocal of the active concentration, log(1/C): 3.94
For compound 4 the middle estimate is 1.06 log units above the measured one, and the stated range ends above it.
By their numbers in this assay, from the lowest: compound 4; then compound 3; then compounds 2 and 1 (each within the scatter of the next).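

In this assay, among these compounds, putting acetyl in place of the carbamate-bearing group on this double-bonded ring carbon gives a number 1.92 log units lower from compound 1 to compound 4 (beyond the scatter), the first change at one place alone, so what sits here clearly matters. The group that leaves is larger and carries a hydrogen-bond donor, and no evidence shows which of these differences, if either, accounts for the step.

As far as these compounds go, whether the carbamate itself is needed, or only a chain of this length, stays open. The same core with a chain ending in a hydroxyl group or an amine would help to separate the two.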